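From Methoxy to Acetoxy: Expecting Little Change

The source may hold more compounds than are shown below. What is called first, only, known or untested is meant among the compounds shown, and "the series" means these compounds.

Measured so far in a functional assay on PC-3 cells (Homo sapiens) for cytotoxicity, read by colorimetric assay and MTT assay; a higher number here means a weaker inhibitor, a lower number a stronger inhibitor:
compound 1 `COc1ccc(-c2cc3c(OC)cc(OC)cc3n(C)c2=O)cc1` gives 10000 nM;
compound 2 `CCN(CC)C(=O)CCn1c(=O)c(-c2ccc(OC)cc2)cc2c(OC)cc(OC)cc21` gives 10000 nM.

Compound 1 stands level with compound 2, as shown by no change at the digits printed from compound 1 to compound 2 (within the scatter). Compound 3 `COc1cc(OC)c2cc(-c3ccc(OC(C)=O)cc3)c(=O)n(C)c2c1` differs from compound 1 by acetyl in place of methyl on an oxygen on an aromatic ring. For the measured compounds named here, no measured step touches this place; the one step known alters a chain on the ring nitrogen instead and was flat. Going by the values given here, with no precedent for the change, the expected step is no change at the digits printed from compound 1 to compound 3 (within the scatter), nothing beyond the scatter. Compound 3 is therefore estimated at 10000 nM, within a range from 3000 nM to 30000 nM.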

Compound 3, half-maximal inhibitory concentration: 10000 nM
Compound 3: the middle estimate sits on the measured number at the digits printed; measured number inside the range.
By their numbers in this assay, from the lowest: compounds 1, 2 and 3 (each within the scatter of the next).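

In this assay, putting acetyl in place of methyl on this oxygen gives no change at the digits printed from compound 1 to compound 3 (within the scatter) at a place the earlier step, on the ring nitrogen, never touched. For the compounds shown here, this is the first reading for this position: methoxy to acetoxy adds a carbonyl and a hydrogen-bond acceptor, yet the number does not move. Nothing available accounts for this flat result.

On these data alone, whether an amine, a carboxylic acid or a longer ester chain at this oxygen would shift the number remains open. As far as these compounds go, the same change on the other methoxy groups of the shared core also remains open.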